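The compounds below may be only part of what the source reports. "The series", "measured", "known", "first", "only" and "open" are said of these compounds alone.

Working notes on the series. Compound 1 `O=c1[nH]cnc2c1c(-c1cc3ccccc3o1)cn2[C@@H]1O[C@H](CO)[C@@H](O)[C@H]1O` is the reference point. In a functional assay on K562 cells (Homo sapiens), read by MTT assay, with a stated time of 72 h (on this read-out lower numbers stand for stronger inhibition and higher numbers for weaker inhibition), compound 1 gives only a limit, > 20000 nM, and not a number. Two further compounds share the same core and the same sugar: compound 2 `CNc1ncnc2c1c(-c1ccoc1)cn2[C@@H]1O[C@H](CO)[C@@H](O)[C@H]1O` and compound 3 `COc1nc(N)nc2c1c(-c1ccsc1)cn2[C@@H]1O[C@H](CO)[C@@H](O)[C@H]1O`. In this assay compound 2 likewise reports only a limit, > 20000 nM. In this assay compound 3 also reports only a limit, > 20000 nM. Within the data shown here, compound 1 therefore stands exactly where every measured value of the set stands, as summed up by the limit of > 20000 nM in this assay, at which 3 of the 3 values shown sit; no measured value here is a number, and no step between measured compounds can be drawn from them.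

The unmeasured compound 4 `O=c1[nH]cnc2c1c(-c1ccccc1)cn2[C@@H]1O[C@H](CO)[C@@H](O)[C@H]1O` differs from compound 1 in one place: phenyl in place of 1-benzofuran-2-yl on an aromatic carbon. Among the measured compounds shown here, with every measured value sitting at the limit, there is no measured step from which the size of this change could be read. In this assay the expectation is a step of none beyond the scatter, in neither direction, with the read-out most likely again a limit rather than a number. Compound 4 is expected to give about 30000 nM, with a range from 8000 nM to 120000 nM. The estimate means an expected step that the limit leaves unreadable from compound 1 to compound 4, that is, none beyond the scatter.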

Compound 4, half-maximal inhibitory concentration: > 20000 nM
Compound 4: no number, only a limit; the forecaster's own chance of this, stated with the estimate: 85%; the middle value is on the limit's open side.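

No step can be read between compound 1 and compound 4, since both report only a limit in this assay: the limit of > 20000 nM in this assay, at which 4 of the 4 values shown sit. The compounds shown leave open whether any change to the aromatic group or the shared core would give a numerical read-out in this assay, and how large any such step would be.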